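Swapping a propyl tail for hydroxymethyl on the biphenyl end

The source may report more compounds than this note shows. Statements on the series, on what has been measured and on what is new or still open speak of the compounds shown alone.

Of the compounds shown here, three have been measured in a functional assay for agonist activity at G protein-coupled receptor 88 (Homo sapiens), read by HTRF and cAMP accumulation; on this read-out higher numbers stand for an effect only at larger amounts of compound and lower numbers for an effect already at smaller amounts. Within the data shown here, compound 1 `CC(C)C[C@H](N)CN(C(=O)[C@@H]1C[C@H]1c1ccccc1)c1ccc(-c2ccccc2)cc1` gives 880 nM, and compound 2 `CC(C)C[C@H](N)CN(C(=O)[C@@H]1C[C@H]1c1ccccc1)c1ccc(-c2ccccc2F)cc1` gives 1600 nM; the single step between them, a 1.8-fold higher number from compound 1 to compound 2 (0.26 log units; within the scatter), is small. Compound 3 `CCCc1ccc(-c2ccc(N(C[C@@H](N)[C@@H](C)CC)C(=O)[C@@H]3C[C@H]3c3ccccc3)cc2)cc1` gives 61 nM, the lowest of the three numbers and well apart from both others. Compound 4 `CC[C@H](C)[C@H](N)CN(C(=O)[C@@H]1C[C@H]1c1ccccc1)c1ccc(-c2ccc(CO)cc2)cc1` differs from compound 3 only by hydroxy in place of ethyl on a saturated chain carbon bound to an aromatic carbon. Among the measured compounds shown here, no measured step touches this kind of change: the one known step concerns a fluoro group elsewhere, so nothing here tells how this assay responds to an oxygen on this chain. Compound 4 is therefore expected to sit between compound 3 and compound 1, with a guessed step of a 4.9-fold higher number from compound 3 to compound 4 (0.69 log units; beyond the scatter). The estimate for compound 4 is 300 nM, between 80 nM and 1200 nM.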

Compound 4, half-maximal effective concentration: 1100 nM
Estimate against measurement, compound 4: 3.7-fold (0.56 log units) below; measured number inside the range.
By their numbers in this assay, from the lowest: compound 3; then compounds 1, 4 and 2 (each within the scatter of the next).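

In this assay, going from 4-propylphenyl to 4-(hydroxymethyl)phenyl gives an 18-fold higher number from compound 3 to compound 4 (1.26 log units; beyond the scatter) and so shows that the number responds strongly to what this chain carries, which the earlier fluoro step, made elsewhere and within the scatter, could not show. Nothing measured here accounts for the size of this step. On these data alone, it remains open whether the hydroxy group itself matters or simply the removal of the ethyl. A methyl, a methoxymethyl or an aminomethyl group on the same aromatic carbon would help separate these two readings.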